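Ethyl to Isopropyl Ester on the Dichlorophenyl Compound

The compounds below may be only part of what the source reports. "The series", "measured", "known", "first", "only" and "open" are said of these compounds alone.

Among the compounds with values here, in a functional assay (aorta) with Oryctolagus cuniculus as the target (a higher number here means a weaker inhibitor, a lower number a stronger inhibitor), compound 3 `CCO/C(O)=C1\C(C)=NC(C)=C(C(=O)OCCCN2C(=O)c3ccccc3S2(=O)=O)C1c1cccc(Cl)c1Cl` gives 1.8 nM, the highest of the three numbers known, though all three lie within the usual scatter of one another. Compound 2 `CC1=NC(C)=C(C(=O)OCCCN2C(=O)c3ccccc3S2(=O)=O)C(c2ccccc2[N+](=O)[O-])/C1=C(\O)OC(C)C` gives 1.2 nM, and compound 1 `CC1=NC(C)=C(C(=O)OCCCN2C(=O)c3ccccc3S2(=O)=O)C(c2cccc([N+](=O)[O-])c2)/C1=C(\O)OC(C)C` gives 1 nM. Within the data shown here, the only measured step, a 1.2-fold higher number from compound 1 to compound 2 (0.08 log units; within the scatter), concerns a different place and stayed within the scatter. Among the measured compounds shown here, compound 4 `CC1=NC(C)=C(C(=O)OCCCN2C(=O)c3ccccc3S2(=O)=O)C(c2cccc(Cl)c2Cl)/C1=C(\O)OC(C)C` differs from compound 3 by methyl in place of hydrogen on a saturated chain carbon bound to an oxygen on an unsaturated carbon and a saturated chain carbon; no measured pair shows this particular change. For the measured compounds named here, the one hint is that compounds 1 and 2 already carry isopropoxy and sit close to compound 3. Compound 4 is therefore expected to show a 1.2-fold lower number from compound 3 to compound 4 (0.08 log units; within the scatter), nothing beyond the scatter. The estimate for compound 4 in this assay is 1.5 nM, within 0.5 nM to 5 nM.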

Compound 4, half-maximal inhibitory concentration: 2.1 nM
The estimate for compound 4 lay 1.4-fold (0.15 log units) below the measured number; the measured number falls inside the stated range.
By their numbers in this assay, from the lowest: compounds 1, 2, 3 and 4 (each within the scatter of the next, the first and the last beyond it).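

In this assay, ethoxy to isopropoxy on the dichlorophenyl compound gives a 1.2-fold higher number from compound 3 to compound 4 (0.07 log units; within the scatter) and so makes no real difference at this position. With isopropoxy kept, 2,3-dichlorophenyl in place of 2-nitrophenyl gives a 1.8-fold higher number from compound 2 to compound 4 (0.24 log units; within the scatter) and also stays within the scatter. Within the data shown here, the same group in place of 3-nitrophenyl gives a 2.1-fold higher number from compound 1 to compound 4 (0.32 log units; beyond the scatter) as the first step here beyond the scatter, though only a modest one.

From the compounds shown here alone, whether a longer chain or a benzyl group in place of isopropyl would keep the number this low stays open. Nothing shown gives a cause for these steps.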